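This account rests on a few compounds, and the source may have more. Where it says the series, first, only, none or still open, it means among the compounds named here.

Compound 3, with the structure `CCNC(=O)NCCC(O)c1cc(Cl)ccc1N`, stands second highest among the three measured compounds in an assay for inhibition of Nitric oxide synthase, inducible (Homo sapiens), read by scintillation counting, with a stated time of 30 min, tested at 1 mM (a lower number here means less inhibition, a higher number more inhibition at the concentration tested (going by the name of the read-out)), where compound 3 gives 33.9%. Its nearest neighbour is compound 1, the structure `CCCNC(=O)NCCC(O)c1ccccc1N`, which lacks the chlorine atom and carries a propyl in place of an ethyl; in this assay compound 1 gives 19%. Furthest away is compound 2, with the structure `CCCNC(=S)NCCC(O)c1cc(Cl)ccc1N`, in which a thiourea replaces the urea; in this assay compound 2 gives 55%.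

The step from compound 3 to compound 4, the structure `CCCNC(=O)NCCC(O)c1cc(Cl)ccc1N`, is methyl in place of hydrogen on a saturated chain carbon, two bonds along the chain from an amide-type nitrogen. Read one bond further out, this is ethyl to propyl, or ethylamino to propylamino.

Within the data shown here, only one measured step exists, and it concerns a different part of the molecule: a number 21.1 percentage points lower from compound 2 to compound 3 (beyond the scatter). Among the measured compounds shown here, no measured pair isolates the ethyl-to-propyl change alone, since compound 1 differs from compound 4 also by the missing chlorine. With so little to go on, the expected step is small. The estimate for compound 4 is 35%, within the range 20% to 50%, corresponding to an expected step of a number 1.1 percentage points higher from compound 3 to compound 4 (within the scatter) that need not rise beyond the scatter.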

Compound 4, a percentage reported as inhibition, at one concentration (the size of the read-out at that concentration, not a potency): 19.6%
The estimate for compound 4 lay 15.4 percentage points above the measured number; the measured number lies below the stated range.
By their numbers in this assay, from the lowest: compounds 1 and 4 (each within the scatter of the next); then compound 3; then compound 2.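

In this assay, among these compounds, the added methyl on the saturated chain carbon gives a number 14.3 percentage points lower from compound 3 to compound 4 (beyond the scatter) and so shows for the first time that going from ethyl to propyl at this end of the molecule is not a neutral change, at least with chloro on the aromatic carbon. Among the compounds shown here, the new compound also supplies the first clean comparison for chloro in place of hydrogen on an aromatic carbon, which gives a number 0.6 percentage points higher from compound 1 to compound 4 (within the scatter) and means that the two propyl ureas read alike in this assay. It likewise separates the thiourea from the urea with the propyl chain held constant, and that swap alone gives a number 35.4 percentage points lower from compound 2 to compound 4 (beyond the scatter) without the chain length also differing, as it did in the earlier step.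

Still open, on these data alone, is how a butyl chain or a branched isopropyl group would read at this position, and whether chloro and hydrogen on the aromatic carbon would also read alike in the ethyl series or with the thiourea. Nothing shown here offers an explanation for any of these steps.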